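Moving the Aryl Ether Side Chain Out by One Carbon

A few compounds are considered here, and "the series" means these few. Any claim that something is new, unique, unknown or untested is made for them only; others in the source may bear on it.

Three compounds have numbers in a functional assay on HEK293 cells for agonist activity at G-protein coupled receptor 39 (Homo sapiens), read by scintillation proximity assay and inositol phosphate accumulation, with a stated time of 75 min, in the presence of a further agent that is not named here; a higher number here means that more compound is needed for the effect, a lower number that less compound is needed. Compound 1 `Cc1nn(-c2ncnc3nc[nH]c23)c2c1C(C(=O)NCc1ccc(F)cc1)CC(=O)N2` gives 4 nM. Compound 2 `Cc1nn(-c2ncnc3nc[nH]c23)c2c1C(OCc1ccc(C(C)C)cc1)CC(=O)N2` gives 5 nM, the second highest of the three numbers, with compound 1 nearest at a gap within the scatter and compound 3 furthest at a gap beyond it. Compound 3 `CC(C)(C)c1cc(C(=O)N/N=C/c2ccc(O)cc2O)[nH]n1`, built on a different core, gives 240 nM. Compounds 1 and 2 thus show nearly the same number, while compound 3 sits well apart from both.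

Compound 4 `Cc1nn(-c2ncnc3nc[nH]c23)c2c1C(OCCc1ccccc1)CC(=O)N2` has not yet been measured in this assay . It differs from compound 2 in one place: benzyl in place of 4-isopropylphenyl on a saturated chain carbon bound to an oxygen on a saturated carbon. For the measured compounds named here, no pair of measured compounds that differ in one place is available, so the size of this step cannot be read from the table and has to be judged from the structural change alone. The author expects a modest rise in the number, from compound 2 to compound 4 , a 3.0-fold higher number from compound 2 to compound 4 (0.48 log units; beyond the scatter), since compound 2 gives 5 nM and the change removes the 4-isopropylphenyl group. Compound 4 is estimated at 15 nM, within a range of 3 nM to 80 nM.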

Compound 4, half-maximal effective concentration: 3 nM
Compound 4: middle estimate off by 5.0-fold (0.70 log units), on the high side; measured number inside the range.
By their numbers in this assay, from the lowest: compounds 4, 1 and 2 (each within the scatter of the next); then compound 3.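

In this assay, exchanging 4-isopropylbenzyl for phenethyl on the ether oxygen gives a 1.7-fold lower number from compound 2 to compound 4 (0.22 log units; within the scatter), a step within the scatter, so the two compounds cannot be told apart. For the compounds shown here, this is the first comparison here between compounds that differ in one place, and it shows that this position accepts both side chains. The aromatic ring can sit one carbon further out, without the isopropyl group, and the number stays within the scatter of the one for compound 2, so neither feature is shown to matter on its own in this pair. Nothing available here explains why the two side chains read alike.

The compounds shown leave open whether an aromatic ring is needed at this position at all, which a cyclohexyl group or a plain alkyl chain in its place would test, and whether a longer chain such as phenylpropyl would keep the number in the same range. They also leave open how an amine or a carboxylic acid on the ring would fare, as both side chains here carry only carbon.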